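A few compounds are considered here, and "the series" means these few. Any claim that something is new, unique, unknown or untested is made for them only; others in the source may bear on it.

Values below are from an ADME assay on THP-1 cells (Homo sapiens) for cytotoxicity, read by WST assay, with a stated time of 24 h; on this read-out higher numbers stand for weaker inhibition and lower numbers for stronger inhibition.

- Compound 1 `COc1ccc(/C=C/c2c(CC=C(C)C)c(O)cc(O)c2CC=C(C)C)cc1` gives 2700 nM in this read-out.
- Compound 2 `C=CC(C)(C)c1cc(/C=C/c2cc(OC)cc(OC)c2)ccc1OC` gives > 10000 nM as a limit, not a number.

Compound 2 has no measured number in this assay, only the limit of > 10000 nM on the weak side of the scale. Its exact standing is therefore open.

The next compound, compound 3 `COc1cc(/C=C/c2ccc(OC)c(CC=C(C)C)c2)cc(OC)c1`, has 3-methylbut-2-en-1-yl in place of 1,1-dimethylprop-2-en-1-yl on an aromatic carbon, ortho to a methoxy group 3-methylbut-2-en-1-yl in place of 1,1-dimethylprop-2-en-1-yl on an aromatic carbon and the same atoms overall.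

Among the compounds with values here, no measured pair in this small set gives the size of such a swap. Compound 1 also carries 3-methylbut-2-en-1-yl and gives 2700 nM on an otherwise different substitution pattern, so a modest move towards stronger inhibition is expected, though it may not exceed the scatter. The estimated change is an at least 1.4-fold lower number from compound 2 to compound 3 (0.15 log units; that floor lies within the scatter) for this pair, and a further limit in place of a number would be no surprise.

Compound 3 is estimated at 7000 nM in this assay, with an expected range from 2500 nM to 15000 nM for the measurement.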

Compound 3, half-maximal inhibitory concentration: > 10000 nM
Compound 3: only a limit was reported; the forecaster's own chance of this, stated with the estimate: 45%; middle value at least 1.4-fold (0.15 log units) away from the limit.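

In this assay, no step can be read between compound 2 and compound 3, because both stand only as limits, not numbers: the limit of > 10000 nM in this assay, at which 2 of the 3 values shown sit.

From the compounds shown here alone, what remains open is how far each of the two compounds lies on the weak side of that limit, and whether 3-methylbut-2-en-1-yl in place of 1,1-dimethylprop-2-en-1-yl changes the read-out at all.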